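Methoxyphenyl position change in the sulfonamide series

The source may report more compounds than this note shows. Statements on the series, on what has been measured and on what is new or still open speak of the compounds shown alone.

Measured so far:
compound 1 `COc1ccc(NS(=O)(=O)c2ccc(N3CCNC3=O)cc2)cc1`: 800 nM
compound 2 `O=C1NCCN1c1ccc(S(=O)(=O)Nc2ccc(C3CCCCC3)cc2)cc1`: > 1000 nM, a limit of the assay, not a number

Going by the values given here, in a functional assay on HT-29 cells (Homo sapiens) for antiproliferative activity, read by sulforhodamine B assay, with a stated time of 48 h (a higher number here means a weaker inhibitor, a lower number a stronger inhibitor), compound 1 gives 800 nM, the only number among the two values shown. Compound 2 sits at the limit of > 1000 nM in this assay, at which 1 of the 2 values shown sits, so its value is a limit and no number. Among the compounds with values here, the single measured step is an at least 1.2-fold higher number from compound 1 to compound 2 (0.09 log units; that floor lies within the scatter); its floor lies within the scatter, so it shows at most a mild weakening when the methoxy is exchanged for a larger group.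

Compound 3 `COc1cccc(NS(=O)(=O)c2ccc(N3CCNC3=O)cc2)c1` keeps every atom of compound 1 and differs only in 3-methoxyphenyl in place of 4-methoxyphenyl on a sulfonamide nitrogen. Within the data shown here, no measured step moves the methoxy from one ring position to another; the step from compound 1 to compound 2 replaces the group rather than shifting it, so it bears only loosely on this change. With that in mind the expected step is a 1.3-fold higher number from compound 1 to compound 3 (0.10 log units; within the scatter), a change of uncertain direction and likely no larger than the scatter, with some chance that the assay again reports only a limit. Compound 3 is therefore estimated at 1000 nM, within 400 nM to 2500 nM.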

Compound 3, half-maximal inhibitory concentration: 120 nM
For compound 3 the middle estimate is 8.3-fold (0.92 log units) above the measured one, and the stated range ends above it.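

Where the methoxy sits on the aromatic group carried by the sulfonamide nitrogen matters in this series: in this assay the exchange of 4-methoxyphenyl for 3-methoxyphenyl gives a 6.7-fold lower number from compound 1 to compound 3 (0.82 log units; beyond the scatter) and lies beyond the scatter, with the same atoms joined differently. Going by these compounds alone, the earlier pair showed nothing of this kind: compound 1 and compound 2 differ in the group itself rather than in where it stands, so this step is the first reading on position alone. The data shown include no measured property that bears on this gain, and the step stands as an observation on these two compounds only.

From the compounds shown here alone, whether the gain of the 3-methoxyphenyl group extends to other substituents remains open: an ethoxy group, a hydroxyl, an amine or a carboxylic acid in place of the methoxy of compound 3 would each test this. Also open, going by these compounds, are how cyclohexyl would read at the position the methoxy holds in compound 3, and whether the position effect persists when the shared core is changed.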